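From bromo to nitro on a growth inhibitor

The source may report more compounds than this note shows. Statements on the series, on what has been measured and on what is new or still open speak of the compounds shown alone.

Of the compounds shown here, three have numbers so far, and the story here starts from compound 1 `N#CCC1=NN=C(c2ccc(Br)cc2)C(CC(=O)c2ccc(Br)cc2)O1`. In a functional assay on NCI-H460 cells (Homo sapiens) for inhibition, read by sulforhodamine B assay, with a stated time of 48 h (a higher number here means a weaker inhibitor of growth, a lower number a stronger inhibitor of growth), compound 1 gives 22100 nM. Compound 3 `N#CCC1=NN=C(c2ccc(Br)cc2)C(Br)O1` gives 38200 nM, which lies within the usual scatter of the value for compound 1, so these two cannot be told apart. Compound 2 `N#CCC(=O)N/N=C(/CBr)c1ccc([N+](=O)[O-])cc1` gives 10300 nM, a lower number than compound 1 shows and one beyond the scatter. Compound 1 therefore stands on the higher side of this small set.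

The next compound, compound 4 `N#CCC1=NN=C(c2ccc([N+](=O)[O-])cc2)C(CC(=O)c2ccc(Br)cc2)O1`, comes from compound 1 by a single change: nitro in place of bromo on an aromatic carbon. In words, nitro takes the place of bromo on an aromatic carbon, para to a large group, so a 4-bromophenyl becomes a 4-nitrophenyl. For the measured compounds named here, no measured pair shows this swap on its own, so the data give no direct guide to its size. Compound 2, at 10300 nM, also carries a 4-nitrophenyl, but it differs from compound 1 in much else and offers only a faint hint towards a lower number. The expectation in this assay is therefore no step beyond the scatter. The estimated change is a 1.2-fold lower number from compound 1 to compound 4 (0.09 log units; within the scatter). For compound 4 the estimated value is 18000 nM, with an expected range from 7000 nM to 45000 nM.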

Compound 4, concentration for 50% growth inhibition: 40000 nM
Compound 4: middle estimate off by 2.2-fold (0.35 log units), on the low side; the measured number falls inside the stated range.
By their numbers in this assay, from the lowest: compound 2; then compounds 1, 3 and 4 (each within the scatter of the next).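

In this assay, for the compounds shown here, the swap of bromo for nitro on the aromatic carbon gives a 1.8-fold higher number from compound 1 to compound 4 (0.26 log units; within the scatter), the first direct reading of this change at this position. The step stays inside the scatter, so compound 1 and compound 4 cannot be told apart, even though nitro brings 3 heavy atoms and 2 hydrogen-bond acceptors where bromo brought 1 heavy atom and no acceptor. On this core, then, a 4-nitrophenyl and a 4-bromophenyl serve equally well as far as this read-out can show, and no measurement of any property bears on this result to explain it.

The shown compounds leave open whether any other group at this place, such as an amine, a carboxylic acid or a methoxy group, would move the number beyond the scatter, since only bromo and nitro can be compared here. As far as these compounds go, it is also open whether the same swap would give a similar step on the other 4-bromophenyl, the one carried by the carbonyl side chain of compound 1, which stays unchanged in compound 4.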